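Sulfonamide nitrogen substitution in a squalene monooxygenase series

The compounds below may be only part of what the source reports. "The series", "measured", "known", "first", "only" and "open" are said of these compounds alone.

Measured so far:
compound 1 `CCN(C/C=C/C#CC(C)(C)C)Cc1cccc(OCCNS(=O)(=O)c2cccs2)c1` — 450 nM
compound 2 `CCN(C/C=C/C#CC(C)(C)C)Cc1cccc(OCCN(C)S(=O)(=O)c2cc(Br)cs2)c1` — 300 nM

In a functional assay on HepG2 cells for inhibition of squalene monooxygenase (Homo sapiens) (on this read-out higher numbers stand for weaker inhibition and lower numbers for stronger inhibition), compound 1 gives 450 nM. Going by the values given here, the only comparison available is compound 2, which in this assay gives 300 nM; the two numbers sit within the scatter of each other, as the step of a 1.5-fold lower number from compound 1 to compound 2 (0.18 log units; within the scatter) shows.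

Compound 3 `CCCN(CCOc1cccc(CN(CC)C/C=C/C#CC(C)(C)C)c1)S(=O)(=O)c1cccs1` has not yet been measured. Compared with compound 1 it carries propyl in place of hydrogen on a sulfonamide nitrogen. Among the compounds with values here, the one measured step that bears on this, the step of a 1.5-fold lower number from compound 1 to compound 2 (0.18 log units; within the scatter), also changes the same sulfonamide nitrogen, from hydrogen to methyl, but combines that with a bromine on the five-membered aromatic ring, so the contribution of the nitrogen substituent alone cannot be separated. That step stayed within the scatter, which gives no ground to expect a large move in either direction from a propyl at the same place.

Compound 3 is therefore expected to land close to compound 1, with the estimated step of a 1.2-fold lower number from compound 1 to compound 3 (0.07 log units; within the scatter), giving an estimate of 380 nM and a likely range from 150 nM to 950 nM.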

Compound 3, half-maximal inhibitory concentration: 170 nM
For compound 3 the middle estimate is 2.2-fold (0.35 log units) above the measured one; measured number inside the range.
By their numbers in this assay, from the lowest: compounds 3, 2 and 1 (each within the scatter of the next, the first and the last beyond it).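

In this assay, going by these compounds alone, the step of a 2.6-fold lower number from compound 1 to compound 3 (0.42 log units; beyond the scatter) isolates the sulfonamide nitrogen, since propyl in place of hydrogen is the only change and the rest of the core of compound 1 stays the same. The earlier pair could not show this, as its change on the same nitrogen came together with a bromine on the five-membered aromatic ring and stayed within the scatter; here a single substitution on this nitrogen moves the number beyond the scatter, modestly and towards stronger inhibition, so the sulfonamide hydrogen is not required for activity on this read-out. Nothing available accounts for this gain, and the data do not separate the loss of the hydrogen from the gain of the propyl.

The compounds shown leave open whether the number follows chain length on this nitrogen, as methyl appears only together with the bromine and nothing longer than propyl, such as butyl or hexyl, is among them. Also open, from the compounds shown here alone, are the response to an amine or a carboxylic acid on the propyl chain and whether the bromine and the propyl would add up in one compound.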